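The source may hold more compounds than are shown below. What is called first, only, known or untested is meant among the compounds shown, and "the series" means these compounds.

Measured in a functional assay on A549 cells (Homo sapiens) for inhibition, read by CCK-8 assay, with a stated time of 72 h, tested at 10 uM; a lower number here means less inhibition of growth, a higher number more inhibition of growth at the concentration tested:
- compound 1 `Cc1cccc(NC(=O)C2(C(=O)Nc3ccc(Nc4ncc5cc(C(=O)N(C)C)n(C6CCCC6)c5n4)cc3)CC2)c1`: 86.1%
- compound 2 `CN(C)C(=O)c1cc2cnc(Nc3ccc(NC(=O)C4(C(=O)Nc5cccc(F)c5)CC4)cc3)nc2n1C1CCCC1`: 91.8%
- compound 3 `CN(C)C(=O)c1cc2cnc(Nc3ccc(NC(=O)C4(C(=O)Nc5ccccc5F)CC4)cc3)nc2n1C1CCCC1`: 88.6%

Compound 3, at 88.6%, cannot be separated from the other two compounds: the steps are a number 2.5 percentage points higher from compound 1 to compound 3 (within the scatter) and a number 3.2 percentage points lower from compound 2 to compound 3 (within the scatter).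

Next is compound 4 `CN(C)C(=O)c1cc2cnc(Nc3ccc(NC(=O)C4(C(=O)Nc5cccc(Cl)c5)CC4)cc3)nc2n1C1CCCC1`, with 3-chlorophenyl in place of 2-fluorophenyl on an amide-type nitrogen.

The measured steps that bear on this change all alter the group on that nitrogen, and the third is a number 5.7 percentage points higher from compound 1 to compound 2 (within the scatter). None exceeds the scatter, so no step beyond the scatter is expected in this assay.

The expected change is a number 1.4 percentage points higher from compound 3 to compound 4 (within the scatter).

For compound 4 the estimate is 90%, with an expected range of 80% to 97%.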

Compound 4, percent growth inhibition at one concentration: 90.7%
Beside the measured number, compound 4's estimate is 0.7 percentage points below it; the measured number falls inside the stated range.
By their numbers in this assay, from the lowest: compounds 1, 3, 4 and 2 (each within the scatter of the next).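

In this assay, 3-chlorophenyl on the amide-type nitrogen cannot be separated from any of the three other aryl groups (a number 2.1 percentage points higher from compound 3 to compound 4 (within the scatter); a number 1.1 percentage points lower from compound 2 to compound 4 (within the scatter); a number 4.6 percentage points higher from compound 1 to compound 4 (within the scatter)). The second and third of these steps, which put chloro where compound 2 carries fluoro and compound 1 carries methyl, thus add two further changes within the scatter, and all four compounds remain within the scatter of one another. No evidence bearing on this result is available.

Still open, as far as these compounds go, is how an amine or a carboxylic acid in place of the halogen on that phenyl would read in this assay. From the compounds shown here alone, whether these four compounds separate at lower concentrations also remains open.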